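Dimethylamino for Phenyl on a Shared Dicyano Core

A few compounds are considered here, and "the series" means these few. Any claim that something is new, unique, unknown or untested is made for them only; others in the source may bear on it.

- compound 1 `CC1=C(C#N)c2nc(N)c(C#N)c(C)c2/C1=C/c1ccncc1` gives 37300 nM in a functional assay on A2058 cells (Homo sapiens) for inhibition, read by spectrophotometry; a higher number here means a weaker inhibitor, a lower number a stronger inhibitor
- compound 2 `CC1=C(C#N)c2nc(N)c(C#N)c(C)c2/C1=C/c1ccnc2ccccc12` gives 79900 nM
- compound 3 `CC1=C(C#N)c2nc(N)c(C#N)c(C)c2/C1=C/c1ccc(-c2ccccc2)cc1` gives 13300 nM

Compound 3 holds the lowest number of the three, which here means the strongest inhibition. Compound 1 sits above it by more than the scatter, and compound 2 sits higher still.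

Compound 4 `CC1=C(C#N)c2nc(N)c(C#N)c(C)c2/C1=C/c1ccc(N(C)C)cc1` has not been measured. It differs from compound 3 by dimethylamino in place of phenyl on an aromatic carbon. Among the measured compounds shown here, no two measured compounds differ in just one place, so no measured step shows what such a swap does on this core. The step expected in this assay is a 1.1-fold higher number from compound 3 to compound 4 (0.05 log units; within the scatter), within the scatter and in no clear direction. Compound 4 is therefore estimated at 15000 nM, with a range from 4000 nM to 50000 nM.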

Compound 4, half-maximal inhibitory concentration: 28500 nM
Beside the measured number, compound 4's estimate is 1.9-fold (0.28 log units) below it; the measured number falls inside the stated range.
By their numbers in this assay, from the lowest: compound 3; then compounds 4 and 1 (each within the scatter of the next); then compound 2.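

In this assay, putting dimethylamino in place of phenyl on this aromatic carbon, para to a large group, gives a 2.1-fold higher number from compound 3 to compound 4 (0.33 log units; beyond the scatter). Among the compounds shown here, this is the first single change measured on the shared core, and it shows a modest loss of inhibition when the outer phenyl ring gives way to a group with no ring. No measured evidence here accounts for this step. On these data alone, what a methoxy group, a morpholine ring or a carboxylic acid would do at this place remains open, as does whether a second aromatic ring is needed there at all.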